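The compounds below may be only part of what the source reports. "The series", "measured", "known", "first", "only" and "open" are said of these compounds alone.

Series read in a functional assay on HT-29 cells (Homo sapiens) for cytotoxicity, read by MTT assay, with a stated time of 24 h; on this read-out lower numbers stand for stronger inhibition and higher numbers for weaker inhibition:

compound 1 `Cn1c(-c2ccc(NC(=O)CCl)cc2)nc(-c2ccccc2)c1-c1ccccc1` gives 28.7 ug/mL
compound 2 `Cn1c(-c2ccc(NC(=O)CSc3nc4cc(Cl)ccc4o3)cc2)nc(-c2ccccc2)c1-c1ccccc1` gives 20.6 ug/mL
compound 3 `Cc1ccc2oc(SCC(=O)Nc3ccc(-c4nc(-c5ccccc5)c(-c5ccccc5)n4C)cc3)nc2c1` gives 22.4 ug/mL

Compound 3 stands second highest of the three numbers; its steps to both neighbours, a 1.3-fold lower number from compound 1 to compound 3 (0.11 log units; within the scatter) and a 1.1-fold higher number from compound 2 to compound 3 (0.04 log units; within the scatter), lie within the scatter, so the three measured compounds are not separated.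

Compound 4 `Cn1c(-c2ccc(NC(=O)CSc3nc4ccccc4s3)cc2)nc(-c2ccccc2)c1-c1ccccc1` differs from compound 3 by 1,3-benzothiazol-2-yl in place of 5-methyl-1,3-benzoxazol-2-yl on a sulfur. Going by the values given here, the steps that bear on it are the two that attach a bicyclic sulfanyl group to the chain carbon, a 1.4-fold lower number from compound 1 to compound 2 (0.14 log units; within the scatter) and a 1.3-fold lower number from compound 1 to compound 3 (0.11 log units; within the scatter), and the one that changes a substituent on that bicycle, a 1.1-fold higher number from compound 2 to compound 3 (0.04 log units; within the scatter): all within the scatter. Among the compounds with values here, no measured step swaps oxygen for sulfur in the five-membered ring, so nothing beyond the scatter is expected in this assay; the expected step is a 1.0-fold lower number from compound 3 to compound 4 (0.01 log units; within the scatter). Compound 4 is estimated at 22 ug/mL, range 12 ug/mL to 40 ug/mL.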

Compound 4, half-maximal inhibitory concentration: 18 ug/mL
Compound 4: the middle estimate sits 1.2-fold (0.09 log units) above what was measured, within the range that was stated.
By their numbers in this assay, from the lowest: compounds 4, 2, 3 and 1 (each within the scatter of the next).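

In this assay sulfur in place of oxygen in the five-membered ring, with no substituent on the bicycle, leaves the number unresolved from both benzoxazole compounds (a 1.2-fold lower number from compound 3 to compound 4 (0.09 log units; within the scatter); a 1.1-fold lower number from compound 2 to compound 4 (0.06 log units; within the scatter)). Set against chloro on the saturated chain carbon, (1,3-benzothiazol-2-yl)sulfanyl also stays within the scatter (a 1.6-fold lower number from compound 1 to compound 4 (0.20 log units; within the scatter)), so this third bicyclic sulfanyl group separates nothing either. No evidence bears on the cause of these small steps. Still open, on these data alone, is whether an amine or a carboxylic acid in place of the sulfanyl group, or a longer chain, moves the number beyond the scatter.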